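A few compounds are considered here, and "the series" means these few. Any claim that something is new, unique, unknown or untested is made for them only; others in the source may bear on it.

In an ADME assay on MT4 cells (Homo sapiens) for cytotoxicity, read by MTT assay, with a stated time of 5 days (a lower number here means that less compound is tolerated, a higher number that more compound is tolerated), only limits are available so far. Compound 1 `COc1ccc(NC(=O)COc2ccnc(Nc3ccc(C#N)cc3)n2)cc1` gives > 333000 nM, which is a limit of the assay and not a number. Compound 2 `Cc1cc(OCC(=O)Nc2ccc(F)cc2)nc(Nc2ccc(C#N)cc2)n1` gives > 331000 nM, which is also a limit. Compound 2 therefore has no exact value, and the one other result beside it is a limit too, so the two cannot be placed in order.

The next compound, compound 3 `Cc1cc(OCC(=O)Nc2ccc([N+](=O)[O-])cc2)nc(Nc2ccc(C#N)cc2)n1`, keeps the structure of compound 2 apart from a single change: nitro in place of fluoro on an aromatic carbon, para to a large group, which turns the 4-fluorophenyl into a 4-nitrophenyl (nitro in place of fluoro on an aromatic carbon). Among the compounds with values here, no measured pair of compounds shows what a single change does in this assay, so this expectation rests on little. No step beyond the usual scatter is expected, although a modest move towards lower numbers is possible, and another limit is the likeliest report. The expected change is an at least 1.5-fold lower number from compound 2 to compound 3 (0.17 log units; that floor lies within the scatter). For compound 3 the estimated value is 220000 nM, with an expected range from 50000 nM to 330000 nM.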

Compound 3, half-maximal cytotoxic concentration: > 309000 nM
Compound 3: only a limit was reported (the forecaster's own chance of this, stated with the estimate: 60%); middle value at least 1.4-fold (0.14 log units) away from the limit.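

In this assay, compound 2 and compound 3 are both reported only as limits and not as numbers, so the step from fluoro to nitro cannot be read. The compounds shown leave open what exact value any of them would give and what a single change does in this assay.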